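Cytotoxicity notes: bromo for fluoro in one amide series

The compounds below may be only part of what the source reports. "The series", "measured", "known", "first", "only" and "open" are said of these compounds alone.

In an ADME assay on Vero cells (Chlorocebus sabaeus) for cytotoxicity, read by resazurin assay, with a stated time of 3 days (on this read-out higher numbers stand for weaker inhibition and lower numbers for stronger inhibition), compound 1 `CCN(CC)c1cc2[nH]c(C3CCCCC3)nc2cc1NC(=O)c1ccc(F)cc1` gives only a limit, > 100 ug/mL. Compound 2 `CN(C)c1cc2[nH]c(C3CCCCC3)nc2cc1NC(=O)c1ccc(F)cc1F` likewise returns only a limit in this assay, > 100 ug/mL. Compound 1 thus stands at the limit of > 100 ug/mL in this assay, at which 2 of the 2 values shown sit, together with compound 2, with no number to rank either of them. Compound 3 `CCN(CC)c1cc2[nH]c(C3CCCCC3)nc2cc1NC(=O)c1ccc(Br)cc1` differs from compound 1 by bromo in place of fluoro on an aromatic carbon. Within the data shown here, no measured step for this change exists, so its size is unknown; the step is expected to be none beyond the scatter, given that compound 1 already sits at the limit of > 100 ug/mL in this assay, at which 2 of the 2 values shown sit. Compound 3 is expected to give 100 ug/mL, within 40 ug/mL to 250 ug/mL. That implies an expected step of a number no higher from compound 1 to compound 3 (the limit leaves the size open).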

Compound 3, half-maximal inhibitory concentration: > 100 ug/mL
Compound 3 gave a limit, no number; the forecaster's own chance of this, stated with the estimate: 70%; the middle value sits exactly at the limit.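

Compound 3, like compound 1, gives only a limit in this assay, so no step can be read for bromo in place of fluoro. The compounds shown leave open whether this change shifts the read-out at all, as each value is a limit: the limit of > 100 ug/mL in this assay, at which 3 of the 3 values shown sit.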